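Phenoxy for furan-2-yl on a carbonyl carbon

The source may report more compounds than this note shows. Statements on the series, on what has been measured and on what is new or still open speak of the compounds shown alone.

Values in a functional assay on NCI-H460 cells (Homo sapiens) for antiproliferative activity; on this read-out higher numbers stand for weaker inhibition and lower numbers for stronger inhibition:
Compound 1 `COc1ccc(S(=O)(=O)Oc2ccccc2NC(=O)c2ccc(F)cc2)cc1` gives 550 nM
Compound 2 `COc1ccc(S(=O)(=O)Oc2ccccc2NC(=O)c2ccco2)cc1` gives 24 nM

Compound 2 holds the lower of the two numbers, well clear of compound 1. Compound 3 `COc1ccc(S(=O)(=O)Oc2ccccc2NC(=O)Oc2ccccc2)cc1`, not yet measured, has phenoxy in place of furan-2-yl on a carbonyl carbon. Among the measured compounds shown here, one measured step bears on this change at that carbonyl carbon, the large 23-fold lower number from compound 1 to compound 2 (1.36 log units; beyond the scatter), where furan-2-yl replaced 4-fluorophenyl. Phenoxy also brings back a six-membered aromatic ring, so a higher number is expected in this assay, probably by a smaller step. The expected change is a 6.3-fold higher number from compound 2 to compound 3 (0.80 log units; beyond the scatter). The estimate for compound 3 is 150 nM, with an expected range of 30 nM to 800 nM.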

Compound 3, half-maximal inhibitory concentration: > 10000 nM
Compound 3 gave a limit, no number; the forecaster's own chance of this, stated with the estimate: 3%; at least 66-fold (1.82 log units) between middle value and limit.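

In this assay compound 3 gives a limit, not a number: the limit of > 10000 nM in this assay, at which 1 of the 3 values shown sits.

Phenoxy on this carbonyl carbon gave an at least 410-fold higher number from compound 2 to compound 3 (2.61 log units; beyond the scatter), and it also fell short of the weaker earlier compound, with an at least 18-fold higher number from compound 1 to compound 3 (1.25 log units; beyond the scatter). A six-membered aromatic ring alone therefore does not account for the loss, since compound 1 carries one and still gives a measurable value. The compounds shown leave open whether the linking oxygen or the ring it carries matters here. A benzyl, anilino or methoxy group on the same carbonyl carbon would separate these.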